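Branching the Chain on the Core Nitrogen

A few compounds are considered here, and "the series" means these few. Any claim that something is new, unique, unknown or untested is made for them only; others in the source may bear on it.

Compound 2, `CCCc1c(OCCCCOc2ccc(-c3nn[nH]n3)cc2)ccc2c1ccn2CCC`, carries a propyl chain on the nitrogen of its core. For the measured compounds named here, in a functional assay for binding affinity to metabotropic glutamate receptor 2 (Homo sapiens), read by GTPgammaS binding, with a stated time of 1 h, at 30 degrees C (a higher number here means that more compound is needed for the effect, a lower number that less compound is needed), compound 2 gives 652 nM, the lowest of the two numbers measured so far. Compound 1, `CCCc1c(OCCCCOc2ccc(-c3nn[nH]n3)cc2)ccc2c1CCN2CC(C)(C)C`, built on a different core, gives 1170 nM in this assay. The gap between compound 1 and compound 2 lies within the scatter of this measurement, so neither can be called the more potent of the two. Compound 3, `CCCc1c(OCCCCOc2ccc(-c3nn[nH]n3)cc2)ccc2c1ccn2CC(C)C`, has not yet been measured. It differs from compound 2 by methyl in place of hydrogen on a saturated chain carbon bound to two saturated chain carbons, which turns the propyl chain into an isobutyl chain. Going by the values given here, with only two measured compounds and no single-point step between them, nothing here points to a shift beyond the scatter. The step of a 1.1-fold lower number from compound 2 to compound 3 (0.04 log units; within the scatter) is therefore expected to be small. Compound 3 is expected to give 600 nM in this assay, with a range from 250 nM to 1500 nM.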

Compound 3, half-maximal effective concentration: 765 nM
Beside the measured number, compound 3's estimate is 1.3-fold (0.11 log units) below it; the measured number falls inside the stated range.
By their numbers in this assay, from the lowest: compounds 2, 3 and 1 (each within the scatter of the next).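

With compound 3 the set gains its first step that changes a single place: in this assay, methyl in place of hydrogen on a saturated chain carbon bound to two saturated chain carbons, which turns propyl into isobutyl, gives a 1.2-fold higher number from compound 2 to compound 3 (0.07 log units; within the scatter). This single step shows that the branched chain can stand in place of the straight one with no readable change in the number, something the earlier pair, with its different cores, could not show. Nothing measured here bears on why the number holds.

For the compounds shown here, this is only one branch on one core, so how far the chain can be altered remains open. The compounds shown do not tell whether a longer chain such as pentyl, a cyclohexylmethyl group or a chain ending in an amine would keep the number within the scatter.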